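A few compounds are considered here, and "the series" means these few. Any claim that something is new, unique, unknown or untested is made for them only; others in the source may bear on it.

Compound 2 `COC(=O)c1ccc2ccc(C(=O)c3ccc(C(F)(F)F)cc3)c-2cc1` is the lowest of the three compounds measured in an assay on cells for displacement of a labelled ligand from Orexin receptor type 2 (Homo sapiens), read by scintillation counting, with stated times of 10 min and 90 min, tested at 10 uM; a lower number here means less inhibition, a higher number more inhibition at the concentration tested (going by the name of the read-out); there compound 2 gives -47.4%. Compound 1 `COC(=O)c1ccc2ccc(C(=O)c3ccccc3)c-2cc1` gives 28.9% in this assay, and compound 3 `O=C(O)c1cccc2c(C(=O)c3ccccc3)cc(C(=O)c3ccc(C(Cl)(Cl)Cl)cc3)c-2c1` gives 25.6%. Within the data shown here, the one step between measured compounds that differ in a single place, a number 76.3 percentage points lower from compound 1 to compound 2 (beyond the scatter), is a large drop, but it concerns the trifluoromethyl group and not the group that changes here. The change now considered, (carboxymethyl in place of methoxycarbonyl on an aromatic carbon), leads to compound 4 `O=C(O)Cc1ccc2ccc(C(=O)c3ccc(C(F)(F)F)cc3)c-2cc1`. Among the measured compounds shown here, no measured pair bears directly on carboxymethyl in place of methoxycarbonyl on an aromatic carbon; compound 3 carries an acid but differs from compound 2 in several places, so its value shows only that an acid-bearing member of this series can sit higher than compound 2. For the measured compounds named here, with no step to lean on, the expectation for compound 4 is a number not far from compound 2, with a wide range, and the expected step of a number 32.4 percentage points higher from compound 2 to compound 4 (beyond the scatter) is modest. Compound 4 is estimated at -15%, within -60% to 30%.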

Compound 4, a percentage reported as inhibition, at one concentration (the size of the read-out at that concentration, not a potency): 11.2%
For compound 4 the middle estimate is 26.2 percentage points below the measured one; the measured number falls inside the stated range.
By their numbers in this assay, from the lowest: compound 2; then compound 4; then compounds 3 and 1 (each within the scatter of the next).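

In this assay, among these compounds, the step from methoxycarbonyl to carboxymethyl on an aromatic carbon of the seven-membered ring gives the first direct reading at this position: a number 58.6 percentage points higher from compound 2 to compound 4 (beyond the scatter), a large step. The read-out at this position therefore responds strongly to how the group is built, even though the two groups hold the same heavy atoms, joined differently, and the rest of the molecule, including the trifluoromethyl group, stays the same. No measurement at hand accounts for this step.

Going by these compounds, whether the step would be of similar size on the core of compound 1, without the trifluoromethyl group, remains open. Also open, on these data alone, is how an amine or a longer chain ending in a carboxylic acid would read at this position.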